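This account rests on a few compounds, and the source may have more. Where it says the series, first, only, none or still open, it means among the compounds named here.

Compound 1 `COc1ccc(C2=C(c3cc(OC)c(OC)c(OC)c3)C(=O)CC2O[SiH2]C(C)(C)C)cc1OC` was tested in an ADME assay on ECV-304 cells (Homo sapiens) for cytotoxicity, read by MTT assay, with a stated time of 72 h; a lower number here means a stronger inhibitor, a higher number a weaker inhibitor. In this assay compound 1 gives > 100 ug/mL, which is a limit of the assay rather than a number. Compound 3 `COc1ccc(C2=C(c3cc(OC)c(OC)c(OC)c3)CC(O)C2=O)cc1N` likewise gives > 100 ug/mL in this assay, again only a limit. Compound 2 `COc1ccc(C2=C(c3cc(OC)c(OC)c(OC)c3)C(=O)C(OC(C)=O)C2)cc1Cl` gives 3.5 ug/mL in this assay. Compound 1 thus stands at the limit of > 100 ug/mL in this assay, at which 2 of the 3 values shown sit. Compound 4 `COc1cc(C2=C(c3cc(C)c(OC)c(C)c3)C(O[SiH2]C(C)(C)C)CC2=O)cc(OC)c1OC` has not yet been measured; it differs from compound 1 by 4-methoxy-3,5-dimethylphenyl in place of 3,4-dimethoxyphenyl on a double-bonded ring carbon. Among the measured compounds shown here, no step between measured compounds is available to size this change, so the expectation rests on compound 1 alone. Compound 4 is expected at 80 ug/mL, between 15 ug/mL and 300 ug/mL, with the expected step of an at least 1.2-fold lower number from compound 1 to compound 4 (0.09 log units; that floor lies within the scatter) no larger than the usual scatter.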

Compound 4, half-maximal inhibitory concentration: 15 ug/mL
Beside the measured number, compound 4's estimate is 5.3-fold (0.73 log units) above it, and the stated range covers the measured number.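

In this assay, 4-methoxy-3,5-dimethylphenyl in place of 3,4-dimethoxyphenyl on a double-bonded ring carbon gives an at least 6.6-fold lower number from compound 1 to compound 4 (0.82 log units; beyond the scatter). Among the compounds shown here, this is the first sized change at this position, and it shows that this single swap, with the rest of the core unchanged, is enough to bring a measurable number. Compound 1 stands at a limit, so the full size of the step is unknown: the limit of > 100 ug/mL in this assay, at which 2 of the 4 values shown sit.

The compounds shown do not tell whether the added methyl groups or the lost methoxy carries the change. On these data alone, how a carboxylic acid or a butoxy chain would read on this aromatic ring also remains open.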